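From isopentyl to 4-methoxybenzyl: notes on compound 4

A few compounds are considered here, and "the series" means these few. Any claim that something is new, unique, unknown or untested is made for them only; others in the source may bear on it.

Measured in an ADME assay on HeLa cells (Homo sapiens) for inhibition, read by MTT assay, with a stated time of 48 h; a lower number here means a stronger inhibitor, a higher number a weaker inhibitor:
- Compound 1 `CCOC(=O)C(=O)CC(=O)/C=C/c1cn(CCC(C)C)c2ccccc12`: "not determined" (no result reported)
- Compound 2 `CCOC(=O)C(=O)CC(=O)/C=C/c1cn(C=C(C)C)c2ccccc12`: "not determined" (no result reported)
- Compound 3 `CC(C)CCn1cc(/C=C/C(=O)CC(=O)C(=O)O)c2ccccc21`: > 80000 nM

Among the compounds with values here, compound 3 is the only compound with a reported result, and its > 80000 nM is a limit, not a number. Within the data shown here, compound 1 and compound 2 offer no result for comparison, and no pair of measured compounds yields a step, so the series provides no step size to carry over.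

Compound 4 `COc1ccc(Cn2cc(/C=C/C(=O)CC(=O)C(=O)O)c3ccccc32)cc1` keeps the shared core of compound 3 and differs in one place: 4-methoxyphenyl in place of isobutyl on a saturated chain carbon bound to an aromatic nitrogen. Here 4-methoxyphenyl stands in place of isobutyl on a saturated chain carbon bound to an aromatic nitrogen, which also reads as isopentyl to 4-methoxybenzyl.

The expectation rests on compound 3 alone, with its limit of > 80000 nM. No step beyond the scatter is expected in this assay, in either direction. The estimate is a step of an at least 1.1-fold lower number from compound 3 to compound 4 (0.05 log units; that floor lies within the scatter). Another limit is the likeliest report. For compound 4 the expected value is 70000 nM, with an estimated range of 25000 nM to 160000 nM.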

Compound 4, half-maximal inhibitory concentration: > 40000 nM
Compound 4: a limit, no number; the forecaster's own chance of this, stated with the estimate: 65%; the middle value does not contradict the limit.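

In this assay compound 3 gives > 80000 nM, a limit. Compound 4 gives > 40000 nM, also a limit, so no step can be read between compound 3 and compound 4. The compounds shown leave open whether 4-methoxyphenyl in place of isobutyl shifts the read-out at all.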